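Biaryl swap at the distal ring: pyridyl to isopropylphenyl

A few compounds are considered here, and "the series" means these few. Any claim that something is new, unique, unknown or untested is made for them only; others in the source may bear on it.

Measured so far in a physicochemical assay for lipophilicity, read by HPLC, at pH 7.5; a lower number here means a more polar compound, a higher number a more lipophilic compound:
- compound 1 `N#Cc1c(-c2ccc(Br)cc2)nc2cnccc2c1NCC(N)=O` gives 1.9
- compound 2 `CC[C@@H](Nc1c(C#N)c(-c2ccc(-c3ncccc3C)cc2)nc2cnccc12)C(N)=O` gives 2

Compound 2 holds the higher of the two numbers in this assay, but its nearest neighbour is compound 1, whose value lies within the scatter of it, so the two read as equal for practical purposes. Among the compounds with values here, no pair of measured compounds differing in a single place is available, so no step size has been measured.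

Compound 3 `CC[C@@H](Nc1c(C#N)c(-c2ccc(-c3ccccc3C(C)C)cc2)nc2cnccc12)C(N)=O` is the next member to be run in this assay. Its difference from compound 2 is as follows: 2-isopropylphenyl in place of 3-methylpyridin-2-yl on an aromatic carbon. A six-membered aromatic ring with one nitrogen and one hydrogen-bond acceptor is exchanged for a ring of carbon only with no acceptor and two more heavy atoms.

Given that, the step in this assay is expected to be upward and well beyond the scatter, with an estimated change of a number 1.30 log units higher from compound 2 to compound 3 (beyond the scatter). Compound 3 is expected to come out around 3.3, with a likely range of 2.8 to 3.8.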

Compound 3, distribution coefficient: 3.5
For compound 3 the middle estimate is 0.20 log units below the measured one; measured number inside the range.
By their numbers in this assay, from the lowest: compounds 1 and 2 (each within the scatter of the next); then compound 3.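

Within the data shown here, this is the first step with a change in one place only: in this assay, 2-isopropylphenyl in place of 3-methylpyridin-2-yl, on an aromatic carbon para to a large group, comes out at a number 1.50 log units higher from compound 2 to compound 3 (beyond the scatter) and counts as large. The read-out at this position therefore responds strongly to the substituent, which compounds 1 and 2 could not show, as they differ in more than one place. Among these compounds, the single exchange removes the ring nitrogen and the hydrogen-bond acceptor and adds two heavy atoms all at once, and no independent measurement is available to assign the step to any one of these.

Still open, as far as these compounds go, is how the step divides between these parts: an unsubstituted phenyl ring, a 2-methylphenyl group or a pyridin-2-yl ring carrying isopropyl would each separate the ring nitrogen from the size of the alkyl group. Also open, from the compounds shown here alone, is how the read-out responds at this position to a group of a different kind, such as an amine or a carboxylic acid, and whether a step of this size recurs on another core.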